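Aryl swap from compound 2 to compound 4

A few compounds are considered here, and "the series" means these few. Any claim that something is new, unique, unknown or untested is made for them only; others in the source may bear on it.

Measured in a functional assay on A549 cells (Homo sapiens) for cytotoxicity, read by MTT assay, with a stated time of 48 h; a lower number here means a stronger inhibitor, a higher number a weaker inhibitor:
- compound 1 `COc1ccc(C2=NOC(COc3ccc(-c4nnnn4-c4cc(OC)c(OC)c(OC)c4)cc3N)C2)cc1N` gives 2080 nM
- compound 2 `COc1cc(C2=NOC(COc3ccc(-c4nnnn4-c4cc(OC)c(OC)c(OC)c4)cc3N)C2)cc(OC)c1OC` gives 2060 nM
- compound 3 `COc1ccc(-c2nnnn2-c2cc(OC)c(OC)c(OC)c2)cc1N` gives 2630 nM

The value of compound 2 lies within the scatter of both compound 1 and compound 3, so the three stand level in this assay on these numbers.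

Compound 4 `COc1cc(-n2nnnc2-c2ccc(OCC3CC(c4ccc(C(F)(F)F)cc4)=NO3)c(N)c2)cc(OC)c1OC` is the next step: 4-(trifluoromethyl)phenyl in place of 3,4,5-trimethoxyphenyl on a carbon with a double bond to nitrogen. In words, 4-(trifluoromethyl)phenyl comes in place of 3,4,5-trimethoxyphenyl on a carbon with a double bond to nitrogen.

One measured step changes the group at this place: a 1.0-fold lower number from compound 1 to compound 2 (0.00 log units; within the scatter), which is within the scatter. Compound 3 lacks this group altogether and still gives 2630 nM in the same range. For the measured compounds named here, no measured compound carries a trifluoromethyl group, so the data do not cover the incoming group directly, and the range is kept wide.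

No change beyond the scatter is expected, and the expected step is a 1.2-fold higher number from compound 2 to compound 4 (0.08 log units; within the scatter) overall. Compound 4 is estimated at 2500 nM with an expected range of 1000 nM to 6500 nM as the working span.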

Compound 4, half-maximal inhibitory concentration: 1220 nM
The estimate for compound 4 lay 2.0-fold (0.31 log units) above the measured number, and the stated range covers the measured number.
By their numbers in this assay, from the lowest: compounds 4, 2, 1 and 3 (each within the scatter of the next, the first and the last beyond it).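

The replacement of 3,4,5-trimethoxyphenyl by 4-(trifluoromethyl)phenyl gives a 1.7-fold lower number from compound 2 to compound 4 (0.23 log units; within the scatter) in this assay, and the replacement of 3-amino-4-methoxyphenyl by the same group gives a 1.7-fold lower number from compound 1 to compound 4 (0.23 log units; within the scatter) in the same read-out. Both steps lie within the scatter, so this place, on a carbon with a double bond to nitrogen, now holds an aryl group with no methoxy group and 0 hydrogen-bond acceptors without a step beyond the scatter. The earlier step from compound 1 to compound 2 covered only methoxy-bearing aryl groups.

Unsubstituted phenyl at this place would separate the departure of the methoxy groups from the arrival of trifluoromethyl. Also open, on these data alone, is whether a saturated ring such as cyclohexyl, or a phenyl ring carrying a carboxylic acid, would stay in the same range.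

No measurement shown here bears on the reason for these numbers.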